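Swapping the Amide Heteroaryl on the Protected Chain Analogue

This account rests on a few compounds, and the source may have more. Where it says the series, first, only, none or still open, it means among the compounds named here.

Compound 2 `Cc1cnc(C(=O)Nc2cc(OCCC3CCN(C(=O)OC(C)(C)C)CC3)cc3cccnc23)cn1` gives 9000 nM in a functional assay on MIA PaCa-2 cells (Homo sapiens) for inhibition, read by MTT assay, with a stated time of 72 h (on this read-out higher numbers stand for weaker inhibition and lower numbers for stronger inhibition), the highest of the three numbers shown. Its nearest neighbour is compound 3 `Cc1cnc(C(=O)Nc2cc(OCCC3CCNCC3)cc3cccnc23)cn1`, which gives 6170 nM; that step reads a 1.5-fold lower number from compound 2 to compound 3 (0.16 log units; within the scatter). Compound 1 `COc1cc(NC(=O)c2cnc(C)cn2)c2ncccc2c1` gives 270 nM, and the step of a 23-fold higher number from compound 1 to compound 3 (1.36 log units; beyond the scatter). Compound 4 `CC(C)(C)OC(=O)N1CCC(CCOc2cc(NC(=O)c3ncccn3)c3ncccc3c2)CC1` differs from compound 2 by pyrimidin-2-yl in place of 5-methylpyrazin-2-yl on a carbonyl carbon. Neither measured step touches the group on the carbonyl carbon: one alters the saturated chain carbon bound to the aromatic-ring oxygen, the other the tert-butoxycarbonyl on the amine nitrogen in a ring. Among the compounds with values here, with no precedent for this change among the measured compounds, the expected step of no change at the digits printed from compound 2 to compound 4 (within the scatter) is none beyond the scatter, though the uncertainty is wide. Compound 4 is therefore estimated at 9000 nM, between 2500 nM and 30000 nM.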

Compound 4, half-maximal inhibitory concentration: > 10000 nM
Compound 4 gave a limit, no number (the forecaster's own chance of this, stated with the estimate: 15%); at least 1.1-fold (0.04 log units) between middle value and limit.
By their numbers in this assay, from the lowest: compound 1; then compounds 3 and 2 (each within the scatter of the next). At a limit, above all of these: compound 4.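

In this assay compound 4 gives > 10000 nM, which is a limit and not a number. Within the data shown here, this is the first view of the group on the carbonyl carbon: pyrimidin-2-yl in place of 5-methylpyrazin-2-yl reads an at least 1.1-fold higher number from compound 2 to compound 4 (0.04 log units; that floor lies within the scatter), so the swap brings no lower number on this protected chain, but its true size stays unread. The reading sits at the limit: the limit of > 10000 nM in this assay, at which 1 of the 4 values shown sits. The compounds shown leave open whether the same swap would read alike on the methoxy core of compound 1. They also leave open how a pyridin-2-yl or a 5-aminopyrazin-2-yl group on that carbonyl carbon would read.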